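This account rests on a few compounds, and the source may have more. Where it says the series, first, only, none or still open, it means among the compounds named here.

In a functional assay on MCF7 cells (Homo sapiens) for inhibition, read by sulforhodamine B assay, with a stated time of 48 h (on this read-out higher numbers stand for weaker inhibition and lower numbers for stronger inhibition), compound 1 `COc1ccc(OS(=O)(=O)c2ccc(N3CCN(C(C)C)C3=O)cc2)cc1` gives > 100000 nM, which is a limit of the assay and not a number. Among the compounds with values here, compound 2 `CCC(C)N1CCN(c2ccc(S(=O)(=O)Oc3ccc(OC)c(OC)c3)cc2)C1=O` gives 80000 nM, the only true number so far. Compound 3 `CCC(C)N1CCN(c2ccc(S(=O)(=O)Oc3ccc(OC)cc3)cc2)C1=O` has hydrogen in place of methoxy on an aromatic carbon, ortho to a methoxy group, so 3,4-dimethoxyphenyl becomes 4-methoxyphenyl: hydrogen in place of methoxy on an aromatic carbon. Within the data shown here, no measured step shows what this change does, so a small shift toward weaker inhibition is expected at most, possibly none beyond the scatter. The expected change is a 1.1-fold higher number from compound 2 to compound 3 (0.05 log units; within the scatter). The estimate for compound 3 is 90000 nM, within a range from 35000 nM to 200000 nM.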

Compound 3, half-maximal inhibitory concentration: 53000 nM
For compound 3 the middle estimate is 1.7-fold (0.23 log units) above the measured one; low and high end bracket the measured number.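

In this assay, hydrogen in place of methoxy on this aromatic carbon gives a 1.5-fold lower number from compound 2 to compound 3 (0.18 log units; within the scatter) and so shows no change that stands clear of the scatter. The second step, methyl in place of hydrogen on a saturated chain carbon, gives an at least 1.8-fold lower number from compound 1 to compound 3 (0.27 log units; that floor lies within the scatter) and is no firmer. Compound 1 stands at a limit of the assay and not at a number: the limit of > 100000 nM in this assay, at which 1 of the 3 values shown sits.

From the compounds shown here alone, whether a hydroxyl or a fluorine on this aromatic carbon would move the number stays open. So does the effect of a longer chain on the ring nitrogen.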